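Swapping the Aryl Group on the Five-Membered Ring

The source may report more compounds than this note shows. Statements on the series, on what has been measured and on what is new or still open speak of the compounds shown alone.

Going by the values given here, compound 2 `CCCCCCCCc1ccc(OCC(=O)Cn2nnnc2-c2ccccc2Cl)cc1` is the weaker of the two compounds measured so far. In an assay on microsomes from brain for inhibition of Fatty-acid amide hydrolase 1 (Rattus norvegicus), read by fluorescence and HPLC, with a stated time of 60 min (on this read-out lower numbers stand for stronger inhibition and higher numbers for weaker inhibition), compound 2 gives 4600 nM. Among the compounds with values here, compound 1 `CCCCCCCCc1ccc(OCC(=O)Cn2nnnc2C)cc1`, which carries a methyl in the same place, gives 41 nM in this assay, so the step of a 110-fold higher number from compound 1 to compound 2 (2.05 log units; beyond the scatter) is the single comparison at hand, and it shows that exchanging methyl for 2-chlorophenyl costs a great deal of inhibition. Compound 3 `CCCCCCCCc1ccc(OCC(=O)Cn2nnnc2-c2ccc(S(=O)(=O)N(C)C)cc2)cc1` is not yet measured. It differs from compound 2 only by 4-(dimethylsulfamoyl)phenyl in place of 2-chlorophenyl on an aromatic carbon. Within the data shown here, the one measured step touching this position runs from a methyl to an aryl group, not from one aryl group to another, so it says little about whether a second aryl group, one carrying a dimethylsulfamoyl group, will fare better or worse than 2-chlorophenyl. As far as these compounds go, with an aryl group kept in place, a large gain back toward compound 1 seems unlikely, while a further loss or no change beyond the scatter both remain open. Compound 3 is therefore expected to give about 5000 nM in this assay, within a range of 1000 nM to 30000 nM, meaning an expected step of a 1.1-fold higher number from compound 2 to compound 3 (0.04 log units; within the scatter) of no size beyond the scatter.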

Compound 3, half-maximal inhibitory concentration: 1400 nM
Compound 3: the middle estimate sits 3.6-fold (0.55 log units) above what was measured, within the range that was stated.
By their numbers in this assay, from the lowest: compound 1; then compound 3; then compound 2.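

The aryl group at this position does not carry one fixed penalty. In this assay the exchange of 2-chlorophenyl for 4-(dimethylsulfamoyl)phenyl gives a 3.3-fold lower number from compound 2 to compound 3 (0.52 log units; beyond the scatter), so the identity of the aryl group matters and not just its presence on the five-membered ring. The recovery is only partial, however: the comparison with the small methyl group remains large at a 34-fold higher number from compound 1 to compound 3 (1.53 log units; beyond the scatter), which places both aryl compounds on the weak side of compound 1, and no measurement here accounts for the difference between the two aryl groups.

The two aryl groups differ in both the substituent and its place on the six-membered ring, so these compounds cannot show whether the change in substituent, the change in its place, or both together produce the step between them. Unsubstituted phenyl, 4-chlorophenyl and 2-(dimethylsulfamoyl)phenyl would separate those two changes, while an ethyl or a cyclopropyl group would show how the numbers run between methyl and a full aryl ring.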